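The source may report more compounds than this note shows. Statements on the series, on what has been measured and on what is new or still open speak of the compounds shown alone.

Of the compounds shown here, three have been measured in an assay on CHO cells for displacement of a labelled ligand from adenosine receptor A1 (Homo sapiens), read by scintillation counting, tested at 10 uM; a higher number here means more inhibition at the concentration tested (going by the name of the read-out), a lower number less inhibition. Compound 1 `CC(C)(C)Cc1c(-c2ccc(Cl)cc2)sc(N)c1C(=O)c1ccc(Cl)cc1` gives 1% in this assay. Compound 2 `CC(C)(C)Cc1c(-c2ccc(Cl)c(Cl)c2)sc(N)c1C(=O)c1ccc(Cl)cc1` gives 1% in this assay, and compound 3 `Cc1noc(C)c1-c1sc(N)c(C(=O)c2ccc(Cl)cc2)c1CC(C)(C)C` gives 1% in this assay. Compound 3 therefore stands level with the other two: no change at the digits printed from compound 1 to compound 3 (within the scatter) and no change at the digits printed from compound 2 to compound 3 (within the scatter), and likewise no change at the digits printed from compound 1 to compound 2 (within the scatter). All three read-outs sit at the bottom of the scale, with nothing to separate them.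

Compound 4 `CC(C)(C)Cc1c(-c2ccco2)sc(N)c1C(=O)c1ccc(Cl)cc1` is the next member and has not been measured. furan-2-yl in place of 3,5-dimethyl-1,2-oxazol-4-yl on an aromatic carbon Of the measured steps, the two that exchanged the group on an aromatic carbon bear most directly on this change: no change at the digits printed from compound 1 to compound 3 (within the scatter) and no change at the digits printed from compound 2 to compound 3 (within the scatter) were both flat, and the smaller exchange no change at the digits printed from compound 1 to compound 2 (within the scatter) was flat as well. No exchange at this position has moved the read-out away from the bottom of the scale so far. The step from compound 3 to compound 4 is therefore expected to stay within the scatter, with no direction to it: a number 1 percentage points higher from compound 3 to compound 4 (within the scatter). For compound 4 the estimate in this assay is 2%, with a range from -8% to 12%.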

Compound 4, a percentage reported as inhibition, at one concentration (the size of the read-out at that concentration, not a potency): 1%
For compound 4 the middle estimate is 1 percentage points above the measured one; low and high end bracket the measured number.
By their numbers in this assay, from the lowest: compounds 1, 2, 3 and 4 (each within the scatter of the next).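

On the aromatic carbon next to the ring sulfur, furan-2-yl brings a five-membered aromatic ring with a single hetero atom and no ring nitrogen, yet this assay shows no change at the digits printed from compound 3 to compound 4 (within the scatter). The comparison with the phenyl groups reads the same, with no change at the digits printed from compound 2 to compound 4 (within the scatter) and no change at the digits printed from compound 1 to compound 4 (within the scatter), so the flat read-out at this position now covers 4-chlorophenyl, 3,4-dichlorophenyl, 3,5-dimethyl-1,2-oxazol-4-yl and furan-2-yl, with no exception among the four compounds. No measurement at hand offers an explanation for this flat read-out.

All four values lie at the bottom of the scale, so these compounds cannot show whether a group of a different kind on this carbon, such as a saturated ring amine, a carboxylic acid or a longer chain, would lift the read-out. The neopentyl group, the (4-chlorophenyl)carbonyl group and the amino group are shared by all four compounds, which leaves open whether exchanging any of them, for instance the amino group for an amide, would change the picture.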